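The source may hold more compounds than are shown below. What is called first, only, known or untested is meant among the compounds shown, and "the series" means these compounds.

Two compounds on the shared core have entries so far, and neither provides a numerical potency. In an ADME assay on HeLa cells (Homo sapiens) for inhibition, read by MTT assay, with a stated time of 48 h (a lower number here means a stronger inhibitor, a higher number a weaker inhibitor), compound 1 `C=C(C)Cn1cc(/C=C/C(=O)CC(=O)C(=O)OCC)c2ccccc21` has the entry "not determined" (no result reported), so it gives no result to compare. Compound 2 `CC(C)CCn1cc(/C=C/C(=O)CC(=O)C(=O)O)c2ccccc21` gives > 80000 nM in this assay, which is a limit of the assay and not a number. Going by the values given here, its standing is therefore only (the limit of > 80000 nM in this assay, at which 1 of the 2 values shown sits), and no measured step connects these two compounds.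

The next compound is compound 3 `C=C(C)Cn1cc(/C=C/C(=O)CC(=O)C(=O)O)c2ccccc21`, which departs from compound 2 in one place: 1-methylethenyl in place of isobutyl on a saturated chain carbon bound to an aromatic nitrogen. In words, 1-methylethenyl stands in place of isobutyl on a saturated chain carbon bound to an aromatic nitrogen. Among the compounds with values here, with no measured step to draw on, the expectation rests on compound 2 alone, whose entry of > 80000 nM is a limit. No change beyond the scatter is expected in this assay, in either direction, and a further limit would be no surprise. The estimated step is a number no higher from compound 2 to compound 3 (the limit leaves the size open). For compound 3, the expected half-maximal inhibitory concentration is 80000 nM, with an estimated range from 35000 nM to 160000 nM.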

Compound 3, half-maximal inhibitory concentration: 40000 nM
Estimate against measurement, compound 3: 2.0-fold (0.30 log units) above, and the stated range covers the measured number.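

In this assay, going by these compounds alone, compound 3 gives 40000 nM, the first single number on the shared core, so this position on a saturated chain carbon bound to an aromatic nitrogen now has a reading that is not a limit. Putting 1-methylethenyl in place of isobutyl, which reads one bond further out as isopentyl to 2-methylprop-2-en-1-yl, gives an at least 2.0-fold lower number from compound 2 to compound 3 (0.30 log units; that floor lies within the scatter), so the data fix only a floor for this change and that floor does not go beyond the usual spread of repeat measurements. The true size of the step stays unknown, as compound 2 has only a limit of the assay to offer: the limit of > 80000 nM in this assay, at which 1 of the 3 values shown sits.

The compounds shown leave open how other groups at this place would read, such as a longer chain, a benzyl group or an amine, and whether any single number would fall well clear of that of compound 3. They also leave open what the ethyl ester does in place of the carboxylic acid, as compound 1 has the entry "not determined" (no result reported) and offers no result to compare.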